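Fluoro in place of hydrogen, carried from compound 1 to compound 2

This account rests on a few compounds, and the source may have more. Where it says the series, first, only, none or still open, it means among the compounds named here.

Compound 1 `O=C(Nc1ccc2c(c1)B(O)OC2)c1ccccc1C(F)(F)F` is measured in a functional assay on PBMC cells (Homo sapiens) for inhibition, read by HTRF, with stated times of 15 min and 24 h (on this read-out lower numbers stand for stronger inhibition and higher numbers for weaker inhibition), at 2100 nM. Compound 3 `O=C(Nc1ccc2c(c1)B(O)OC2)c1c(F)cccc1C(F)(F)F` differs from it by fluoro in place of hydrogen on an aromatic carbon and gives 180 nM in this assay, a step of a 12-fold lower number from compound 1 to compound 3 (1.07 log units; beyond the scatter). Compound 2 `O=C(Nc1ccc2c(c1)B(O)OC2)c1ccc(C(F)(F)F)cc1` has the same atoms as compound 1 joined differently; the difference between the two cores is not broken down here. In this assay compound 2 reaches only a limit, > 100000 nM, as recorded in the limit of > 100000 nM in this assay, at which 1 of the 3 values shown sits. Compound 4 `O=C(Nc1ccc2c(c1)B(O)OC2)c1ccc(C(F)(F)F)cc1F` carries fluoro in place of hydrogen on an aromatic carbon, the same change as from compound 1 to compound 3, with both place descriptions matching word for word. From compound 2 to compound 4 a step of an at least 4.0-fold lower number from compound 2 to compound 4 (0.60 log units; beyond the scatter) is expected, resting on the measured 12-fold lower number from compound 1 to compound 3 (1.07 log units; beyond the scatter); as compound 2 has only a limit, the starting point is uncertain and the expectation wide. Compound 4 is therefore estimated at 25000 nM, between 4000 nM and 150000 nM.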

Compound 4, half-maximal inhibitory concentration: > 100000 nM
Compound 4 ended at the assay's limit; the forecaster's own chance of this, stated with the estimate: 35%; at least 4.0-fold (0.60 log units) between middle value and limit.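

Compound 2 and compound 4 both stand at a limit, so no step between them can be read: the limit of > 100000 nM in this assay, at which 2 of the 4 values shown sit.

The compounds shown leave open whether fluoro in place of hydrogen changes the number at all in the setting of compound 2.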